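The source may hold more compounds than are shown below. What is called first, only, known or untested is meant among the compounds shown, and "the series" means these compounds.

Measured in a functional assay on HT-29 cells (Homo sapiens) for inhibition, with a stated time of 72 h; a higher number here means a weaker inhibitor, a lower number a stronger inhibitor:
- Compound 1 `COc1ccc(S(=O)(=O)N2CCc3cccc(-c4ccc(N)cc4)c32)cc1`: 301 nM
- Compound 2 `COc1ccc(S(=O)(=O)N2CCc3cccc(-c4ccc(F)nc4)c32)cc1`: 109 nM
- Compound 3 `COc1ccc(S(=O)(=O)N2CCc3cccc(-c4ccc([N+](=O)[O-])cc4)c32)cc1`: 51.8 nM

Of these three, compound 3 gives the lowest number, 51.8 nM. The steps leading to it, a 2.1-fold lower number from compound 2 to compound 3 (0.32 log units; beyond the scatter) and a 5.8-fold lower number from compound 1 to compound 3 (0.76 log units; beyond the scatter), both lie beyond the scatter.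

The next compound, compound 4 `COc1ccc(S(=O)(=O)N2CCc3cccc(-c4ccc(N(C)C)cc4)c32)cc1`, keeps the shared core and has dimethylamino in place of nitro on an aromatic carbon, para to a large group (dimethylamino in place of nitro on an aromatic carbon). The same difference can be read as 4-nitrophenyl to 4-(dimethylamino)phenyl.

The measured step that bears most directly on this is a 5.8-fold lower number from compound 1 to compound 3 (0.76 log units; beyond the scatter), a modest one with nitro in place of amino. Read backwards, it suggests that losing the nitro group may raise the number in this assay. Going by the values given here, compound 1, which carries the amino group, gives 301 nM, but no dimethylamino compound has been measured, so the match with amino remains uncertain. A modest rise is therefore expected, probably smaller than the full amino step. The estimated change is a 2.9-fold higher number from compound 3 to compound 4 (0.46 log units; beyond the scatter). For compound 4 the expected value is 150 nM, with an estimated range from 45 nM to 500 nM.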

Compound 4, half-maximal inhibitory concentration: 467 nM
For compound 4 the middle estimate is 3.1-fold (0.49 log units) below the measured one; measured number inside the range.
By their numbers in this assay, from the lowest: compound 3; then compound 2; then compounds 1 and 4 (each within the scatter of the next).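

Replacing nitro with dimethylamino on this aromatic carbon, para to a large group, produces the largest step yet seen at this position in this assay (a 9.0-fold higher number from compound 3 to compound 4 (0.95 log units; beyond the scatter)), and the same 4-(dimethylamino)phenyl group also separates from the 6-fluoropyridin-3-yl group beyond the scatter (a 4.3-fold higher number from compound 2 to compound 4 (0.63 log units; beyond the scatter)). The earlier compounds shown here held only one amine at this place, and the new comparison shows that adding the two methyl groups on its nitrogen gives no readable change (a 1.6-fold higher number from compound 1 to compound 4 (0.19 log units; within the scatter)), so amino and dimethylamino stand level here and both sit apart from nitro. Nothing available explains why these groups separate in this way.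

From the compounds shown here alone, it remains open where a methylamino or acetamido group would fall at the same place, and so whether any group carrying nitrogen bonded directly to the ring can match nitro. Going by these compounds, it is equally open whether a nitrile, a carboxylic acid or a methyl ester would stay close to compound 3, or whether the low number of compound 3 is particular to nitro.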